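This account rests on a few compounds, and the source may have more. Where it says the series, first, only, none or still open, it means among the compounds named here.

Compound 1 `Cc1ccc(C2=NN(C3=NC(c4ccccc4)CS3)C(c3ccc4ccccc4c3)C2)cc1C` is one of three compounds tested in a functional assay on HepG2 cells (Homo sapiens) for inhibition, read by CCK-8 assay, with a stated time of 48 h (on this read-out higher numbers stand for weaker inhibition and lower numbers for stronger inhibition), where compound 1 gives 7370 nM. On the numbers shown it stands second highest of the three, though no step separates it from the others beyond the scatter. Its nearest neighbour is compound 2 `Cc1ccc(C2=NN(C3=NC(c4ccccc4)CS3)C(c3cccc4ccccc34)C2)cc1C`, which in this assay gives 7250 nM; the step is a 1.0-fold lower number from compound 1 to compound 2 (0.01 log units; within the scatter), a swap of the naphthalene group on a saturated ring carbon. Furthest away is compound 3 `Cc1ccc(C2=NN(C3=NC(=O)CS3)C(c3ccc4ccccc4c3)C2)cc1C`, which in this assay gives 8490 nM; the step is a 1.2-fold higher number from compound 1 to compound 3 (0.06 log units; within the scatter), an exchange of the group on the ring amine nitrogen.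

The unmeasured compound 4 `COc1ccc(C2=NN(C3=NC(c4ccccc4)CS3)C(c3ccc4ccccc4c3)C2)cc1` differs from compound 1 as follows: 4-methoxyphenyl in place of 3,4-dimethylphenyl on a carbon with a double bond to nitrogen. Neither measured step touches this place, so no direct guide exists; both measured changes elsewhere on the shared core left the number within the scatter. The expectation is therefore a step in this assay of about a 1.0-fold higher number from compound 1 to compound 4 (0.00 log units; within the scatter), which is none beyond the scatter, in no preferred direction. Compound 4 is expected to give roughly 7400 nM in this assay, between 3700 nM and 14800 nM.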

Compound 4, half-maximal inhibitory concentration: 12600 nM
Beside the measured number, compound 4's estimate is 1.7-fold (0.23 log units) below it; the measured number falls inside the stated range.
By their numbers in this assay, from the lowest: compounds 2, 1, 3 and 4 (each within the scatter of the next).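

This is the only view so far of the group on the carbon with a double bond to nitrogen, and in this assay putting 4-methoxyphenyl in place of 3,4-dimethylphenyl gives a 1.7-fold higher number from compound 1 to compound 4 (0.23 log units; within the scatter) and so stays within the usual scatter of repeated measurements. On this single pair, then, a change at this position that keeps the heavy-atom count the same but brings in an oxygen and a hydrogen-bond acceptor does not separate the two compounds, just as the two earlier changes elsewhere on the shared core did not separate theirs. Nothing measured here bears on what lies behind the size of this step.

One pair cannot tell whether a different kind of group at this position, such as a pyridine ring, an aminophenyl or a carboxylic acid on the phenyl ring, would give a step beyond the scatter. Going by these compounds, it also remains open whether 4-methoxyphenyl would give a similar number on the core of compound 2 or compound 3, which carry the other changes seen so far.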